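This account rests on a few compounds, and the source may have more. Where it says the series, first, only, none or still open, it means among the compounds named here.

Working notes on the series in an assay on CHO cells for inhibition of sphingosine kinase 1 (Homo sapiens), tested at 10 uM; on this read-out lower numbers stand for less inhibition and higher numbers for more inhibition at the one concentration tested (going by the name of the read-out). Compound 1, `CCCCCCCCC#C[C@@H](O)[C@@H](N)CO`, carries the long saturated chain and gives 13.7%. Compound 2, `CCCCC#CC(=O)[C@H](CO)NC(=O)OC(C)(C)C`, with the short chain, a ketone and the carbamate, is reported as "not active" (no number reported). Compound 3, `CCCCC#C[C@@H](O)[C@@H](N)CO`, is the short-chain analogue of compound 1. Compound 3 is likewise reported as "not active" (no number reported). Compound 3 thus stands without a single number in this assay; it shares that standing with compound 2, and only compound 1 has a reported figure.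

Compound 4, `CCCCC#C[C@@H](O)[C@H](C)N`, is not yet measured. Relative to compound 3 the change is hydrogen in place of hydroxy on a saturated chain carbon, two bonds along the chain from an amine nitrogen. Among the measured compounds shown here, no measured pair tracks this change, so no size of step can be read from the data. The expectation is that compound 4 stays near compound 3, that is, a change of no size beyond the scatter in this assay, with the short chain of compound 3 and compound 2 giving no reason to expect a reported number.

For compound 4 in this assay the estimate is 6%, in the range 0% to 22%.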

Compound 4, a percentage reported as inhibition, at one concentration (the size of the read-out at that concentration, not a potency): 4.85%
Compound 4: middle estimate off by 1.2 percentage points, on the high side; measured number inside the range.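

Among the compounds shown here, compound 3 has no single number in this assay, so no step from it to compound 4 can be read. The compounds shown leave open what hydroxy to hydrogen does to this read-out on the long chain of compound 1. No data at hand bear on the result.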